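The source may hold more compounds than are shown below. What is called first, only, known or untested is meant among the compounds shown, and "the series" means these compounds.

Working notes on the series. In a functional assay on CHO.K1 cells for antagonist activity at prostaglandin D2 receptor 2 (Homo sapiens), read by GTPgammaS binding, with a stated time of 1 h (on this read-out lower numbers stand for stronger inhibition and higher numbers for weaker inhibition), compound 1 `Cc1c(Cc2cc(Br)ccc2S(=O)(=O)c2ccccc2)c2c(n1CC(=O)O)CCNC2=O` gives 3.9 nM. Compound 2 `COc1cccc(S(=O)(=O)c2ccccc2)c1Cc1c2c(n(CC(=O)O)c1C)CCNC2=O` gives 4500 nM in the same assay. Compound 3 `Cc1c(Cc2ccccc2S(=O)(=O)c2ccc(Cl)cc2)c2c(n1CC(=O)O)CCNC2=O` gives 8.5 nM, which is the second highest of the three numbers: compound 1 is its nearest neighbour, with the lower number, and compound 2 its furthest, with the higher number; both gaps lie beyond the scatter.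

Compound 4 `Cc1c(Cc2ccccc2Oc2ccccc2)c2c(n1CC(=O)O)CCNC2=O` has not yet been measured in this assay. It differs from compound 3 as follows: phenoxy in place of (4-chlorophenyl)sulfonyl on an aromatic carbon. Among the compounds with values here, every measured compound keeps a sulfonyl-linked aryl arm, so no measured pair bears directly on this change, and the step size rests on judgement alone. The step is expected to be a loss well beyond the scatter, a 14-fold higher number from compound 3 to compound 4 (1.15 log units; beyond the scatter). Compound 4 is estimated at 120 nM, within 20 nM to 1000 nM.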

Compound 4, half-maximal inhibitory concentration: 530 nM
Compound 4: middle estimate off by 4.4-fold (0.65 log units), on the low side; the measured number falls inside the stated range.
By their numbers in this assay, from the lowest: compound 1; then compound 3; then compound 4; then compound 2.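

Phenoxy in place of (4-chlorophenyl)sulfonyl on this aromatic carbon, ortho to a large group, gives a 62-fold higher number from compound 3 to compound 4 (1.79 log units; beyond the scatter) in this assay. Within the data shown here, this is the first direct reading at this position, and it shows that the arm cannot be exchanged here without a large loss. Nothing available accounts for the size of this loss.

The exchange replaces the sulfonyl link and removes the chlorine together, so the step does not apportion the loss between them. A chlorine-bearing phenoxy arm or an amine link would separate these contributions.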